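A methoxycarbonyl to benzyloxycarbonyl step on compound 2

The source may hold more compounds than are shown below. What is called first, only, known or untested is meant among the compounds shown, and "the series" means these compounds.

- Compound 1 (`C=C1C(=O)[C@]23C[C@@]1(O)CC[C@H]2[C@@]12C=CC(=O)[C@](C)(C(=O)O1)[C@H]2[C@@H]3C(=O)OCc1ccccc1`): 20500 nM
- Compound 2 (`C=C1C(=O)[C@]23C[C@@]1(I)CC[C@H]2[C@@]12C=CC(=O)[C@](C)(C(=O)O1)[C@H]2[C@@H]3C(=O)OC`): 87000 nM

In a functional assay on HepG2 cells (Homo sapiens) for cytotoxicity, read by MTT assay (on this read-out higher numbers stand for weaker inhibition and lower numbers for stronger inhibition), compound 2 has the higher of the two numbers. Compound 1 lies below it by a gap beyond the usual scatter, which makes compound 2 the weaker inhibitor of the pair. Compound 3 (`C=C1C(=O)[C@]23C[C@@]1(I)CC[C@H]2[C@@]12C=CC(=O)[C@](C)(C(=O)O1)[C@H]2[C@@H]3C(=O)OCc1ccccc1`) has not yet been measured. It departs from compound 2 by a single change, phenyl in place of hydrogen on a saturated chain carbon bound to an oxygen next to a carbonyl group, which turns methoxycarbonyl into benzyloxycarbonyl. Going by the values given here, no measured pair isolates this change, so the data do not fix its size in this assay. Compound 1, which also bears benzyloxycarbonyl, gives 20500 nM, and that single value points to a downward move. A moderate drop toward stronger inhibition is therefore expected, and the estimated step is a 2.5-fold lower number from compound 2 to compound 3 (0.40 log units; beyond the scatter). For compound 3 the estimated value is 35000 nM, with an expected range from 12000 nM to 85000 nM.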

Compound 3, half-maximal inhibitory concentration: 69500 nM
Beside the measured number, compound 3's estimate is 2.0-fold (0.30 log units) below it; low and high end bracket the measured number.
By their numbers in this assay, from the lowest: compound 1; then compounds 3 and 2 (each within the scatter of the next).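

In this assay, going by these compounds alone, compounds 2 and 3 form the one pair that isolates the exchange of methoxycarbonyl for benzyloxycarbonyl, and the step is a 1.3-fold lower number from compound 2 to compound 3 (0.10 log units; within the scatter), so with iodo on the saturated ring carbon the two compounds cannot be told apart on this read-out. Compound 3 also forms a pair with compound 1, which isolates the other place, and with benzyloxycarbonyl held fixed the step is a 3.4-fold higher number from compound 1 to compound 3 (0.53 log units; beyond the scatter). Of the two single changes now readable, only iodo in place of hydroxy on a saturated ring carbon gives a step beyond the scatter, while no measurement shown here accounts for either result.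

The compounds shown leave open whether phenyl in place of hydrogen on this saturated chain carbon would give a similarly small step with hydroxy rather than iodo on the ring carbon, as the one pair in hand carries iodo. They also leave open how a carboxylic acid or a longer chain such as phenylethoxycarbonyl at the benzyloxycarbonyl place, or an amine in place of iodo or hydroxy on the saturated ring carbon, would read in this assay.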